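Butyl in Place of Chloro: An Untested Step

The source may hold more compounds than are shown below. What is called first, only, known or untested is meant among the compounds shown, and "the series" means these compounds.

Compound 2 `Nc1ccc(-c2cc(Cl)cc(C(=O)Nc3nn[nH]n3)n2)cc1` was tested in a functional assay on the whole organism with Rattus norvegicus as the target, at a dose of 0.3 mg/kg by the oral route (a higher number here means a stronger effect of the compound at the dose given, a lower number a weaker effect), where compound 2 gives 39%. For the measured compounds named here, its only neighbour, compound 1 `CCCc1ccc(-c2cc(Cl)cc(C(=O)Nc3nn[nH]n3)n2)cc1`, gives 42% in this assay, and the step of a number 3 percentage points lower from compound 1 to compound 2 (within the scatter) is within the scatter, so the two numbers cannot be told apart. Compound 3 `CCCCc1cc(C(=O)Nc2nn[nH]n2)nc(-c2ccc(N)cc2)c1` is not yet measured. The change from compound 2 to compound 3 is butyl in place of chloro on an aromatic carbon. Going by the values given here, no measured step bears on this change: the one step in hand, a number 3 percentage points lower from compound 1 to compound 2 (within the scatter), concerns amino in place of propyl and leaves the chloro untouched. Among the compounds with values here, with no precedent for exchanging the chloro, no step beyond the scatter is expected in this assay in either direction, and the range is kept wide. Compound 3 is therefore estimated at 40%, between 15% and 65%, a step of a number 1 percentage points higher from compound 2 to compound 3 (within the scatter) that is expected to stay within the scatter.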

Compound 3, a percentage reported as inhibition, in the whole organism at one dose (the size of the read-out at that dose, not a potency): 41%
Beside the measured number, compound 3's estimate is 1 percentage points below it, within the range that was stated.
By their numbers in this assay, from the lowest: compounds 2, 3 and 1 (each within the scatter of the next).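

In this assay the exchange of chloro for butyl, opposite the ring nitrogen, gives a number 2 percentage points higher from compound 2 to compound 3 (within the scatter), so the two compounds cannot be told apart at the dose given. The earlier compounds shown here differed only at the other end of the molecule and both kept the chloro, whereas this pair shows that a group of 4 heavy atoms can stand at this position in place of a group of 1 heavy atom with the read-out staying within the scatter. No independent measurement accounts for this result.

The compounds shown leave open whether a longer chain such as octyl, or a group of another kind such as a carboxylic acid or an amine, would keep the read-out at this position. A single oral dose also leaves open whether compound 2 and compound 3 would still be indistinguishable at other doses.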